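The source may report more compounds than this note shows. Statements on the series, on what has been measured and on what is new or still open speak of the compounds shown alone.

Of the compounds shown here, three of a shared core have been measured in a functional assay on HCT-116 cells (Homo sapiens) for inhibition, read by MTT assay, with a stated time of 48 h; on this read-out lower numbers stand for stronger inhibition and higher numbers for weaker inhibition. Compound 1 `Clc1ccccc1CSc1nnc(-c2ccncc2)n1-c1ccccc1` gives 13900 nM, compound 2 `Clc1cccc(CSc2nnc(-c3ccncc3)n2-c2ccccc2)c1` gives 9820 nM, and compound 3 `COc1ccc(/C=N/NC(=O)CSc2nnc(-c3ccncc3)n2-c2ccccc2)cc1` gives 19200 nM. In this assay the three numbers all lie within the usual scatter of one another, so compound 3 cannot be set apart from the others. Compound 4 `O=C(CSc1nnc(-c2ccncc2)n1-c1ccccc1)N/N=C/c1ccccc1F` differs from compound 3 by 2-fluorophenyl in place of 4-methoxyphenyl on a carbon with a double bond to nitrogen. Among the compounds with values here, no measured step touches this part of the molecule; the only measured step, a 1.4-fold lower number from compound 1 to compound 2 (0.15 log units; within the scatter), concerns a different group and stayed within the scatter. Compound 4 is therefore expected to show no step beyond the scatter, a 1.1-fold lower number from compound 3 to compound 4 (0.05 log units; within the scatter). Compound 4 is estimated at 17000 nM, within a range from 6000 nM to 50000 nM.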

Compound 4, half-maximal inhibitory concentration: 18000 nM
For compound 4 the middle estimate is 1.1-fold (0.02 log units) below the measured one, and the stated range covers the measured number.
By their numbers in this assay, from the lowest: compounds 2, 1, 4 and 3 (each within the scatter of the next).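

Unlike the only earlier step, which concerned a different group, this one touches the carbon with a double bond to nitrogen: in this assay, 2-fluorophenyl in place of 4-methoxyphenyl gives a 1.1-fold lower number from compound 3 to compound 4 (0.03 log units; within the scatter). Here the two groups are thus interchangeable within the scatter, even though the hydrogen-bond acceptor counted for 4-methoxyphenyl is absent from 2-fluorophenyl. No evidence offers an explanation for this result.

The compounds shown leave open how a phenyl ring carrying an amine or a carboxylic acid would read at this carbon. They also leave open whether any group here can move the number beyond the scatter.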